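Series notes: swapping the aryl group on the ring nitrogen

The compounds below may be only part of what the source reports. "The series", "measured", "known", "first", "only" and "open" are said of these compounds alone.

Three measured compounds share one core and differ in the aryl group on an amine nitrogen in a ring and in the aryl of the carbonyl. Compound 1 `Nc1scc(CN2CCN(c3ccc(Cl)c(C(F)(F)F)c3)CC2)c1C(=O)c1ccc(Cl)cc1` gives -47% in a functional assay on CHO cells with adenosine receptor A1 (Homo sapiens) as the target, read by cAMP accumulation and immunoassay, with a stated time of 6 min, tested at 1 uM; a lower number here means a stronger effect, a higher number a weaker effect of the compound at the concentration tested. Compound 2 `Nc1scc(CN2CCN(c3ccc(C(F)(F)F)cc3)CC2)c1C(=O)c1cccc(C(F)(F)F)c1` gives -27%, and compound 3 `Nc1scc(CN2CCN(c3cccc(F)c3)CC2)c1C(=O)c1cccc(C(F)(F)F)c1` gives -35%. Compound 1 thus stands lowest of the three, nearest to compound 3 and beyond the scatter from both. For the measured compounds named here, the only step that bears on the aryl on the ring nitrogen is a number 8 percentage points lower from compound 2 to compound 3 (within the scatter), which barely moved the read-out. Compound 4 `Nc1scc(CN2CCN(c3cccc(F)c3F)CC2)c1C(=O)c1ccc(Cl)cc1` differs from compound 1 by 2,3-difluorophenyl in place of 4-chloro-3-(trifluoromethyl)phenyl on an amine nitrogen in a ring. On that precedent no shift beyond the scatter is expected. Compound 4 is therefore estimated at -42%, within -60% to -22%. The expected step is a number 5 percentage points higher from compound 1 to compound 4 (within the scatter).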

Compound 4, a percentage reported as activity, at one concentration (the size of the read-out at that concentration, not a potency): -66%
Compound 4: middle estimate off by 24 percentage points, on the high side; measured number outside the range, below it.
By their numbers in this assay, from the lowest: compound 4; then compound 1; then compounds 3 and 2 (each within the scatter of the next).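

In this assay, the aryl group on the amine nitrogen in a ring can move the read-out beyond the scatter: the change shows a number 19 percentage points lower from compound 1 to compound 4 (beyond the scatter), unlike the earlier a number 8 percentage points lower from compound 2 to compound 3 (within the scatter). The lower number comes with the smaller 2,3-difluorophenyl, which has fewer heavy atoms than the leaving 4-chloro-3-(trifluoromethyl)phenyl, so on this core the larger aryl is not required for it. No measurement at hand explains the shift. Since chlorine, trifluoromethyl and both fluorines differ in one step, the substituent responsible remains unassigned. From the compounds shown here alone, how a methoxy group or an amine on this aryl would read also remains open.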